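The compounds below may be only part of what the source reports. "The series", "measured", "known", "first", "only" and "open" are said of these compounds alone.

Series notes. Compound 1 `COc1ccc(-c2sc(N)c(C(=O)c3ccc(Cl)cc3)c2C)cc1` and compound 2 `CC(C)(C)Cc1c(-c2cccnc2)sc(N)c1C(=O)c1ccc(Cl)cc1` share one core. In an assay on CHO cells for displacement of a labelled ligand from adenosine receptor A3 (Homo sapiens), read by scintillation counting, tested at 10 uM (a higher number here means more inhibition at the concentration tested (going by the name of the read-out), a lower number less inhibition), compound 1 gives 1% and compound 2 gives 1%, so compound 2 stands level with compound 1 at the digits shown, within the scatter. Compound 3 `Cc1ccccc1-c1sc(N)c(C(=O)c2ccc(Cl)cc2)c1CC(C)(C)C` follows from compound 2 by one change: 2-methylphenyl in place of pyridin-3-yl on an aromatic carbon. Among the measured compounds shown here, no measured pair isolates this change, so it has no precedent here. The step expected in this assay is a number 1 percentage points higher from compound 2 to compound 3 (within the scatter), nothing beyond the scatter in either direction, since compound 2 already gives 1%. For compound 3 the estimate in this assay is 2%, from -8% to 14%.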

Compound 3, a percentage reported as inhibition, at one concentration (the size of the read-out at that concentration, not a potency): 1%
Compound 3: middle estimate off by 1 percentage points, on the high side, and the stated range covers the measured number.
By their numbers in this assay, from the lowest: compounds 1, 2 and 3 (each within the scatter of the next).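

Compound pair evidence: with 2-methylphenyl in place of pyridin-3-yl on the aromatic carbon next to the ring sulfur, this assay shows no change at the digits printed from compound 2 to compound 3 (within the scatter). This first one-place pair shows that exchanging the nitrogen-bearing ring for a carbon-only ring with a methyl group leaves the read-out unmoved, though compound 2 gives only 1%, so the pair has little room to show a loss. Nothing available bears on the reason for this result. Open, going by these compounds, is whether an amine or a carboxylic acid at this position would give inhibition beyond the scatter. Also open, on these data alone, is whether any such gain would depend on the neopentyl group.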